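A few compounds are considered here, and "the series" means these few. Any claim that something is new, unique, unknown or untested is made for them only; others in the source may bear on it.

Working notes on the amide series. Compound 1 `CCCCCCCCCCCCCCCCCC(=O)N1CCOCC1` in a functional assay on PC-3 cells (Homo sapiens) for antiproliferative activity, read by sulforhodamine B assay, with a stated time of 48 h (on this read-out lower numbers stand for stronger inhibition of growth and higher numbers for weaker inhibition of growth), gives 41.1 ug/mL; compound 3 `CCCCCCCCCCCCCCCCCC(=O)N1CCCC1` gives 9.4 ug/mL; compound 2 `CCCCCCCC/C=C\CCCCCCCC(=O)N1CCCC1` gives 13 ug/mL. Compound 2 sits second highest of the three, close to compound 3 and well below compound 1. The next member, compound 4 `CCCCCCCC/C=C\CCCCCCCC(=O)N1CCOCC1`, differs from compound 2 by morpholin-4-yl in place of pyrrolidin-1-yl on a carbonyl carbon. Among the measured compounds shown here, the one measured step that bears on this is the reverse exchange on the saturated chain, a 4.4-fold lower number from compound 1 to compound 3 (0.64 log units; beyond the scatter), a modest step beyond the scatter. Applying it in reverse, a higher number is expected for compound 4, as a step of a 4.2-fold higher number from compound 2 to compound 4 (0.63 log units; beyond the scatter). Compound 4 is therefore estimated at 55 ug/mL, with a range from 25 ug/mL to 130 ug/mL.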

Compound 4, concentration for 50% growth inhibition: 5.2 ug/mL
Compound 4: the middle estimate sits 11-fold (1.02 log units) above what was measured, outside the stated range (below it).
By their numbers in this assay, from the lowest: compounds 4, 3 and 2 (each within the scatter of the next, the first and the last beyond it); then compound 1.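

In this assay, morpholin-4-yl in place of pyrrolidin-1-yl on a carbonyl carbon gives a 2.5-fold lower number from compound 2 to compound 4 (0.40 log units; beyond the scatter), so among the compounds shown, the direction of this change depends on the core that carries it. The two pairs point in opposite directions, and the gap between them exceeds the scatter: the same change on two cores in this assay, a 4.4-fold lower number (0.64 log units; beyond the scatter) from compound 1 to compound 3 and a 2.5-fold higher number (0.40 log units; beyond the scatter) from compound 4 to compound 2, 11-fold (1.04 log units) apart, beyond the scatter of two such steps

The compounds shown leave open whether this reversal extends to other groups on a carbonyl carbon, such as piperidin-1-yl or diethylamino. They also leave open whether it holds on a longer chain.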